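Piperazine dithiocarbamate triazoles: aryl swap at the benzylic position

The source may report more compounds than this note shows. Statements on the series, on what has been measured and on what is new or still open speak of the compounds shown alone.

Measured so far in a functional assay on ECa-109 cells (Homo sapiens) for inhibition, read by MTT assay, with a stated time of 72 h; a lower number here means a stronger inhibitor, a higher number a weaker inhibitor:
compound 1 `COc1ccc(Cn2cc(CSC(=S)N3CCNCC3)nn2)cc1`: > 128000 nM
compound 2 `CC(C)(C)OC(=O)N1CCN(C(=S)SCc2cn(Cc3cc(=O)oc4cc(O)ccc34)nn2)CC1`: > 128000 nM
compound 3 `COc1ccc(Cn2cc(CSC(=S)N3CCN(C(=O)OCc4ccccc4)CC3)nn2)cc1`: 58300 nM

Compound 1, with a free ring amine, reaches only the limit of this assay. Compound 2, differing from it at both the ring amine nitrogen and the group on the saturated chain carbon, also gives a limit. Among the compounds with values here, compound 3 is the one measured number in the set, and the one step available, an at least 2.1-fold lower number from compound 1 to compound 3 (0.34 log units; beyond the scatter), shows that capping the ring amine moves the series off the limit. Two of the three values sit at the same limit (the limit of > 128000 nM in this assay, at which 2 of the 3 values shown sit).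

Compound 4 `S=C(SCc1cn(Cc2ccccc2Cl)nn1)N1CCNCC1` keeps the free ring amine of compound 1 and changes only the aryl group: 2-chlorophenyl in place of 4-methoxyphenyl on a saturated chain carbon bound to an aromatic nitrogen. Within the data shown here, no measured step touches this position; the single step concerns the ring amine nitrogen instead and gives no guidance on the aryl group. With the ring amine left uncapped, as in compound 1, compound 4 is expected to stay at or near the limit, so the step of an at least 1.0-fold lower number from compound 1 to compound 4 (0.02 log units; that floor lies within the scatter) is expected to be none beyond the scatter. The estimate for compound 4 in this assay is therefore 120000 nM, within 40000 nM to 300000 nM.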

Compound 4, half-maximal inhibitory concentration: > 128000 nM
Compound 4 gave a limit, no number; the forecaster's own chance of this, stated with the estimate: 65%; middle value at least 1.0-fold (0.02 log units) away from the limit.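

In this assay compound 4 gives > 128000 nM, a limit and not a number. Compound 1 also stands at a limit, so no step can be read between compound 1 and compound 4. The compounds shown leave open whether 2-chlorophenyl and 4-methoxyphenyl differ in any way once the ring amine carries a cap such as that of compound 3.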